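This account rests on a few compounds, and the source may have more. Where it says the series, first, only, none or still open, it means among the compounds named here.

Measured so far:
- compound 1, `O=C(O)CCc1ccc(C#Cc2ccccc2)cc1`, 200 nM
- compound 2, `O=C(O)CCc1ccc(OCc2cccc(Br)c2)cc1`, 89.1 nM

Both numbers come from a functional assay on 1321-N1 cells for agonist activity at Free fatty acid receptor 1 (Homo sapiens), read by calcium flux; on this read-out higher numbers stand for an effect only at larger amounts of compound and lower numbers for an effect already at smaller amounts. Compound 2 stands at the lower of the two; the number for compound 1 is a little above it, and that gap lies beyond the scatter.

Compound 3, `O=C(O)CCc1ccc(OCc2cccc(-c3ccccc3)c2)cc1`, has not yet been measured. It differs from compound 2 by phenyl in place of bromo on an aromatic carbon. For the measured compounds named here, no measured pair shows this kind of change, so the step in this assay expected from compound 2 to compound 3 is a small one, not clearly beyond the scatter, and if anything downward: a 1.5-fold lower number from compound 2 to compound 3 (0.17 log units; within the scatter). Compound 3 is expected at 60 nM, within 15 nM to 250 nM.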

Compound 3, half-maximal effective concentration: 135 nM
Estimate against measurement, compound 3: 2.3-fold (0.35 log units) below; the measured number falls inside the stated range.
By their numbers in this assay, from the lowest: compounds 2, 3 and 1 (each within the scatter of the next, the first and the last beyond it).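

In this assay, phenyl in place of bromo on this aromatic carbon, meta to a large group, gives a 1.5-fold higher number from compound 2 to compound 3 (0.18 log units; within the scatter). This position therefore accepts a whole six-membered aromatic ring as readily as a single bromine, with no shift that can be told from the scatter. Nothing at hand explains why the much larger group leaves the number in place.

Still open, going by these compounds, is whether a saturated ring such as cyclohexyl, or an amine or a carboxylic acid, would be accepted on this carbon. Also open, on these data alone, is whether phenyl would fare the same on other carbons of that ring.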